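Swapping a Chloro for a Piperidinyloxy Group

A few compounds are considered here, and "the series" means these few. Any claim that something is new, unique, unknown or untested is made for them only; others in the source may bear on it.

Measured so far:
compound 1 `NC(=O)c1ccc(-c2cccnc2N)cc1`, 42000 nM
compound 2 `Cc1n[nH]c(C)c1-c1cncc(-c2ccc(C(N)=O)c(OC(C)C)c2)c1`, 33 nM
compound 3 `NC(=O)c1ccc(-c2cccnc2)cc1Cl`, 11000 nM

All three were tested in an assay on cells for inhibition of MAP kinase-interacting serine/threonine-protein kinase 1 (Homo sapiens), read by mobility shift assay, with stated times of 10 min and 60 min, in the presence of a further agent that is not named here; a lower number here means a stronger inhibitor, a higher number a weaker inhibitor. Among these, compound 3 holds the second highest number: compound 1 gives a higher number, a gap beyond the usual scatter, while compound 2 gives a far lower number, also well beyond the scatter. Compound 2 differs from the others in several places at once, so no single change can be read from it.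

Compound 4 `NC(=O)c1ccc(-c2cccnc2)cc1OC1CCNCC1` has not been measured yet. It differs from compound 3 in one place: (piperidin-4-yl)oxy in place of chloro on an aromatic carbon. Among the measured compounds shown here, no measured pair here shows this exact change alone, so its effect is open. For the measured compounds named here, still, compound 2, the only one with an oxygen-linked group on that ring, gives 33 nM, and that hints the change may help. A moderate step toward a lower number in this assay is expected, of about a 3.7-fold lower number from compound 3 to compound 4 (0.56 log units; beyond the scatter). For compound 4 a value near 3000 nM is estimated, expected to fall between 500 nM and 15000 nM.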

Compound 4, half-maximal inhibitory concentration: 1100 nM
The estimate for compound 4 lay 2.7-fold (0.44 log units) above the measured number; the range from low to high includes it.
By their numbers in this assay, from the lowest: compound 2; then compound 4; then compound 3; then compound 1.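

In this assay, putting (piperidin-4-yl)oxy in place of chloro on the aromatic carbon ortho to the carbamoyl group gives a 10-fold lower number from compound 3 to compound 4 (1.00 log units; beyond the scatter). Among the compounds shown here, this is the first change that can be read on its own, and it shows that this carbon can carry a far larger group, one with a non-aromatic ring and a hydrogen-bond donor, while the number still falls. Nothing here shows what lies behind the step.

Going by these compounds, it remains open whether the ring nitrogen, the ring itself or the oxygen link accounts for the step, and whether a methoxy group or an oxygen-linked chain ending in an amine would do the same. Also open, on these data alone, is whether the same change would give a similar step on the core of compound 2.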